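Swapping an oxazole for a pyrimidine on an aryl amine

This account rests on a few compounds, and the source may have more. Where it says the series, first, only, none or still open, it means among the compounds named here.

Compound 1 `c1csc(-c2ccccc2NCC2=NCCN2)c1`: 18.2 nM
Compound 2 `Cc1nc(-c2ccccc2NCC2=NCCN2)co1`: < 5020 nM, a limit
Compound 3 `Cc1cc(-c2ccccc2NCC2=NCCN2)on1`: < 100000 nM, a limit

In a functional assay for activation of Alpha-1D adrenergic receptor (Homo sapiens) (a lower number here means that less compound is needed, a higher number that more compound is needed for the effect), compound 1 gives 18.2 nM. For compound 2 only a limit is known, < 5020 nM. For compound 3 the result is likewise only a limit, < 100000 nM. Compound 2 thus stands at the limit of < 5020 nM in this assay, at which 1 of the 3 values shown sits, with no exact number of its own. Compound 4 `c1cnc(-c2ccccc2NCC2=NCCN2)nc1` differs from compound 2 by pyrimidin-2-yl in place of 2-methyl-1,3-oxazol-4-yl on an aromatic carbon. The steps that could guide this change, a step that the limit leaves unreadable from compound 1 to compound 2 and a step that the two limits leave unreadable from compound 2 to compound 3, cannot be sized because their endpoints rest at the limit of < 5020 nM in this assay, at which 1 of the 3 values shown sits, and (the limit of < 100000 nM in this assay, at which 1 of the 3 values shown sits). Going by the values given here, the only firm anchor is compound 1, so a wide range is warranted. Compound 4 is expected to give 400 nM, within 30 nM to 5000 nM. The expected step is a step that the limit leaves unreadable from compound 2 to compound 4.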

Compound 4, half-maximal effective concentration: 81.3 nM
Compound 4: the middle estimate sits 4.9-fold (0.69 log units) above what was measured, and the stated range covers the measured number.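

Besides compound 1, compound 4 is the only compound here with an exact number, and it shows that pyrimidin-2-yl can replace thiophen-2-yl at this position with only a modest loss: in this assay there is a 4.5-fold higher number from compound 1 to compound 4 (0.65 log units; beyond the scatter). Compound 2 stands at a limit: the limit of < 5020 nM in this assay, at which 1 of the 4 values shown sits. Compound 3 also stands at a limit: the limit of < 100000 nM in this assay, at which 1 of the 4 values shown sits.

On these data alone, the steps that link compound 4 to compound 2 and compound 3 cannot be read, so how pyrimidin-2-yl ranks against the two methyl oxazoles stays open. Also open, as far as these compounds go, is how an amine on the pyrimidine ring would fare.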